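Swapping a ring-nitrogen substituent for an amide

This account rests on a few compounds, and the source may have more. Where it says the series, first, only, none or still open, it means among the compounds named here.

Measured so far in an assay on membranes from striatum (strain Sprague-Dawley) for displacement of a labelled ligand from sodium-dependent dopamine transporter (Rattus norvegicus), read by scintillation counting, with a stated time of 120 min; on this read-out higher numbers stand for weaker inhibition and lower numbers for stronger inhibition:
Compound 1 `Fc1ccc(C(SCCNC2CCN(Cc3ccc(C(F)(F)F)cc3)CC2)c2ccc(F)cc2)cc1` gives 190 nM.
Compound 2 `[O-][S+](CCNC1CCN(CC(O)Cc2ccccc2)CC1)C(c1ccc(F)cc1)c1ccc(F)cc1` gives 91.8 nM.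
Compound 3 `O=C(C1CC1)N1CCC(NCCSC(c2ccc(F)cc2)c2ccc(F)cc2)CC1` gives 178 nM.

Compound 2 has the lowest number of the three; compound 3 sits within the scatter of it, while compound 1 lies beyond it. Compound 4 `CC(C)(C)C(=O)N1CCC(NCC[S+]([O-])C(c2ccc(F)cc2)c2ccc(F)cc2)CC1` differs from compound 2 by (tert-butyl)carbonyl in place of 2-hydroxy-3-phenylpropyl on an amine nitrogen in a ring. Among the compounds with values here, one measured step bears on this exchange at the same ring nitrogen, a benzyl group replaced by a carbonyl-linked group: a 1.1-fold lower number from compound 1 to compound 3 (0.03 log units; within the scatter). That step left the number essentially unchanged, so no step beyond the scatter is expected here either. Compound 4 is therefore estimated at 110 nM, with a range from 45 nM to 270 nM. The expected step of a 1.2-fold higher number from compound 2 to compound 4 (0.08 log units; within the scatter) is accordingly small.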

Compound 4, inhibition constant: 10200 nM
Estimate against measurement, compound 4: 93-fold (1.97 log units) below; the whole stated range lies below it.
By their numbers in this assay, from the lowest: compounds 2, 3 and 1 (each within the scatter of the next, the first and the last beyond it); then compound 4.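

In this assay the ring nitrogen proves far from indifferent to its substituent: replacing 2-hydroxy-3-phenylpropyl with (tert-butyl)carbonyl brings a 110-fold higher number from compound 2 to compound 4 (2.05 log units; beyond the scatter) and marks this as a sensitive position. A carbonyl-linked group at this nitrogen is therefore not tolerated in every pair, although the exchange for cyclopropylcarbonyl showed only a 1.1-fold lower number from compound 1 to compound 3 (0.03 log units; within the scatter) in the earlier pair.

Nothing shown accounts for this large step. On these data alone, whether it follows from losing 2-hydroxy-3-phenylpropyl or from gaining (tert-butyl)carbonyl stays open, and a plain 3-phenylpropyl chain or an acetyl group on the same nitrogen would help separate the two.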